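Methyl in place of hydrogen on the benzylidene phenyl

The compounds below may be only part of what the source reports. "The series", "measured", "known", "first", "only" and "open" are said of these compounds alone.

Measured so far:
compound 1 `O=C1/C(=C/c2ccccc2)CCC/C1=C\c1cccc([N+](=O)[O-])c1` — 2290 nM
compound 2 `Cc1ccc(/C=C2\CCC/C(=C\c3ccccc3[N+](=O)[O-])C2=O)cc1` — 6090 nM

In a functional assay on CCRF-CEM cells (Homo sapiens) for cytotoxicity, with a stated time of 72 h (a higher number here means a weaker inhibitor, a lower number a stronger inhibitor), compound 1 gives 2290 nM, the lowest of the two numbers. Compound 2 gives 6090 nM in this assay, a higher number, beyond the scatter. Compound 3 `Cc1ccc(/C=C2\CCC/C(=C\c3cccc([N+](=O)[O-])c3)C2=O)cc1` is not yet measured. It differs from compound 1 by methyl in place of hydrogen on an aromatic carbon, read one bond further out as phenyl to 4-methylphenyl. Going by the values given here, no measured pair shows this change on its own. The step is expected to be small, a 1.3-fold higher number from compound 1 to compound 3 (0.12 log units; within the scatter), with no change beyond the scatter. Compound 3 is expected to give 3000 nM, in the range 1200 nM to 7500 nM.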

Compound 3, half-maximal inhibitory concentration: 10100 nM
Compound 3: middle estimate off by 3.4-fold (0.53 log units), on the low side; measured number above the stated range.
By their numbers in this assay, from the lowest: compound 1; then compounds 2 and 3 (each within the scatter of the next).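

Methyl in place of hydrogen on the aromatic carbon, read as phenyl to 4-methylphenyl, gives a 4.4-fold higher number from compound 1 to compound 3 (0.64 log units; beyond the scatter) in this assay. Going by these compounds alone, this is the only single-change step, and it shows that this position, para to a large group, does not take a methyl without a modest loss. No data at hand bear on why the number rises.

From the compounds shown here alone, whether the loss is particular to methyl remains open, since a fluorine, a methoxy or an amine at this place would test that. One pair also cannot show whether the step holds with the nitro group placed as in compound 2.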